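One Chloro Substitution, Seen Twice on a Shared Core

The compounds below may be only part of what the source reports. "The series", "measured", "known", "first", "only" and "open" are said of these compounds alone.

Compound 1 `Nc1scc(-c2ccc(F)cc2)c1C(=O)c1ccccc1` and compound 3 `Nc1scc(-c2ccc(F)cc2)c1C(=O)c1ccc(Cl)cc1` share a core and differ only by chloro in place of hydrogen on an aromatic carbon. In a functional assay on CHO cells for agonist activity at adenosine receptor A1 (Homo sapiens), read by fluorescence and ERK phosphorylation, with stated times of 30 min and 1.5 h, tested at 10 uM (a lower number here means a weaker effect, a higher number a stronger effect of the compound at the concentration tested), compound 1 gives 60%, while compound 3 gives 61%; the resulting step is a number 1 percentage points higher from compound 1 to compound 3 (within the scatter). Compound 2 `Nc1scc(-c2ccc3ccccc3c2)c1C(=O)c1ccccc1` is built on a different core, and the difference between the two cores is not broken down here. In this assay compound 2 gives 73%, the highest of the three numbers and beyond the scatter from both compound 1 and compound 3.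

Compound 4 `Nc1scc(-c2ccc3ccccc3c2)c1C(=O)c1ccc(Cl)cc1` has not yet been measured. It differs from compound 2 by chloro in place of hydrogen on an aromatic carbon, which is the same change already seen from compound 1 to compound 3, at a place described in exactly the same words. Because a number 1 percentage points higher from compound 1 to compound 3 (within the scatter) stayed within the scatter, the same change is expected to yield a similarly small step here, a number 1 percentage points higher from compound 2 to compound 4 (within the scatter). Compound 4 is therefore estimated to reach about 74% in this assay, most likely between 62% and 85%.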

Compound 4, a percentage reported as activity, at one concentration (the size of the read-out at that concentration, not a potency): 67%
The estimate for compound 4 lay 7 percentage points above the measured number, and the stated range covers the measured number.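

In this assay the change from phenyl to 4-chlorophenyl on the core of compound 2 gives a number 6 percentage points lower from compound 2 to compound 4 (within the scatter), so on neither core does adding the chloro group move the read-out beyond ordinary repeat variation. Set side by side, the two steps cannot be told apart, and the change carries from one core to the other without a visible difference: the same change on two cores in this assay, a number 1 percentage points higher (within the scatter) from compound 1 to compound 3 and a number 6 percentage points lower (within the scatter) from compound 2 to compound 4, 7 percentage points apart, within the scatter of two such steps This does not prove that chloro has no effect at all or that the two cores will always respond alike, as the read-out is taken at one concentration and gives no potency, and two cores are too few for a general rule.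

The compounds shown carry only hydrogen or chloro at this place, so it remains open whether a methoxy group, an amine or a carboxylic acid there would give a step beyond the scatter. As far as these compounds go, it also remains open whether chloro would behave the same way on further cores.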